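This account rests on a few compounds, and the source may have more. Where it says the series, first, only, none or still open, it means among the compounds named here.

Measured compounds:
- Compound 1, `COc1ccc(OC)c(/C=C/c2nnc(Nc3ccc(Cl)cc3)o2)c1`: in a functional assay on ACHN cells (Homo sapiens) for antiproliferative activity, read by sulforhodamine B assay, with a stated time of 48 h (on this read-out higher numbers stand for weaker inhibition of growth and lower numbers for stronger inhibition of growth), compound 1 gives 19900 nM.
- Compound 2, `COc1ccc(OC)c(/C=C/C(=O)N/N=C/c2ccc(Cl)cc2)c1`: in this assay compound 2 gives > 100000 nM, which is a limit of the assay and not a number.

Compound 2 therefore stands at the limit of this assay, as the limit of > 100000 nM in this assay, at which 1 of the 2 values shown sits, shows; no number is known for it, only that it lies at that limit. Compound 1 and compound 2 differ in more than one place, so their values can only be set side by side without reading a step from them.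

Compound 3, `COc1ccc(OC)c(/C=C/C(=O)N/N=C/c2ccccc2)c1`, differs from compound 2 by hydrogen in place of chloro on an aromatic carbon. No measured step of this kind is available among the compounds shown. With compound 2 sitting at the limit, the step from compound 2 to compound 3 is expected to be small, a step that the limit leaves unreadable from compound 2 to compound 3, and not beyond the usual scatter in either direction. Compound 3 is accordingly estimated at 150000 nM, between 50000 nM and 500000 nM, and it is expected that compound 3 may again return only a limit rather than a number.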

Compound 3, concentration for total growth inhibition: > 100000 nM
Compound 3 ended at the assay's limit; the forecaster's own chance of this, stated with the estimate: 70%; the middle value is on the limit's open side.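

Compound 2 and compound 3 both stand at a limit in this assay and not at a number, so no step can be read between them. The compounds shown leave open how far each lies from that limit, and whether going from 4-chlorophenyl to phenyl changes growth inhibition at all.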